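Working notes: aryl variation on the shared core

The source may report more compounds than this note shows. Statements on the series, on what has been measured and on what is new or still open speak of the compounds shown alone.

Three compounds of this series have numbers. Compound 1 `O=C(O)CC/C=C\CC1COC(c2ccc(Cl)cc2Cl)OC1c1cccnc1` gives 42 nM in an assay for inhibition of Thromboxane-A synthase (Homo sapiens), using microsomes; a higher number here means a weaker inhibitor, a lower number a stronger inhibitor. Among the measured compounds shown here, compound 2 `O=C(O)CC/C=C\CC1COC(c2ccsc2)OC1c1cccnc1` gives 500 nM in this assay, and the single one-place step, a 12-fold higher number from compound 1 to compound 2 (1.08 log units; beyond the scatter), is the only measured change recorded so far. Compound 3 `COc1ccc(OC(C)(C)C2OCC(C/C=C\CCC(=O)O)C(c3cccnc3)O2)cc1` gives 41 nM in this assay; it has the lowest of the three numbers, and its nearest neighbour is compound 1, whose number is within the scatter of it, while compound 2 lies beyond the scatter above both.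

The next member, compound 4 `CC(C)(Oc1ccccc1Br)C1OCC(C/C=C\CCC(=O)O)C(c2cccnc2)O1`, is not yet measured. The change from compound 3 is 2-bromophenyl in place of 4-methoxyphenyl on an oxygen on a saturated carbon. For the measured compounds named here, no measured step alters an aryl group on an oxygen on a saturated carbon, so nothing bears on it directly; the step from compound 1 to compound 2 concerns an aryl group on a saturated ring carbon and shows only that an aryl swap can move the number substantially. With compound 1 carrying a halogenated phenyl and giving 42 nM, a step of no more than modest size is expected, in either direction or none beyond the scatter. For compound 4 the expected step is a 1.5-fold higher number from compound 3 to compound 4 (0.17 log units; within the scatter). Compound 4 is estimated at 60 nM, with a range from 20 nM to 180 nM.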

Compound 4, half-maximal inhibitory concentration: 29 nM
Compound 4: the middle estimate sits 2.1-fold (0.32 log units) above what was measured; the range from low to high includes it.
By their numbers in this assay, from the lowest: compounds 4, 3 and 1 (each within the scatter of the next); then compound 2.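

In this assay, among the compounds shown here, the first measured change of an aryl group on an oxygen on a saturated carbon gives a 1.4-fold lower number from compound 3 to compound 4 (0.15 log units; within the scatter), so 2-bromophenyl and 4-methoxyphenyl cannot be told apart at this position. The swap removes the one hydrogen-bond acceptor counted on the leaving group and replaces a group of 8 heavy atoms with one of 7, and the number stays within the scatter, in contrast to the large aryl step at the other place, a 12-fold higher number from compound 1 to compound 2 (1.08 log units; beyond the scatter). No measured information explains why this swap leaves the number within the scatter.

With a single step at this position, the bromine and its place on the ring cannot be separated from the loss of the methoxy group, and 2-methoxyphenyl or 4-bromophenyl on the same oxygen would be needed to pull these apart. How far the tolerance extends also remains open, since the compounds shown say nothing about an unsubstituted phenyl, a ring bearing an amine or a saturated cyclohexyl group in this place.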